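Chloro to Fluoro on the Sulfonyl Aryl Ring

The source may hold more compounds than are shown below. What is called first, only, known or untested is meant among the compounds shown, and "the series" means these compounds.

Compound 1 `CC1CCN(c2c(S(=O)(=O)c3cccc(Cl)c3)cnc3cc(Cl)ccc23)CC1`: 92%
Compound 2 `CC1CCN(c2c(S(=O)(=O)c3ccc(F)c(Cl)c3)cnc3cc(F)ccc23)CC1`: 94%

In an assay on isolated protein for displacement of a labelled ligand from metabotropic glutamate receptor 5 (Homo sapiens), with a stated time of 60 min, tested at 1 uM (on this read-out higher numbers stand for more inhibition at the one concentration tested (going by the name of the read-out) and lower numbers for less inhibition), compound 2 gives 94%, the higher of the two numbers shown, though compound 1 with 92% sits within the scatter of it, so no order can be read between them. Compound 3 `CC1CCN(c2c(S(=O)(=O)c3ccc(F)c(F)c3)cnc3cc(F)ccc23)CC1` has not been measured. It differs from compound 2 in one place: fluoro in place of chloro on an aromatic carbon. With both measured values near the top of this read-out, the step is expected to be small, downward or none beyond the scatter. Compound 3 is estimated at 89%, between 72% and 98%, which would be a step of a number 5 percentage points lower from compound 2 to compound 3 (within the scatter).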

Compound 3, a percentage reported as inhibition, at one concentration (the size of the read-out at that concentration, not a potency): 94%
Compound 3: the middle estimate sits 5 percentage points below what was measured; the measured number falls inside the stated range.
By their numbers in this assay, from the lowest: compounds 1, 2 and 3 (each within the scatter of the next).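

In this assay, the change from 3-chloro-4-fluorophenyl to 3,4-difluorophenyl gives no change at the digits printed from compound 2 to compound 3 (within the scatter), so this aromatic carbon, ortho to a fluoro group, accepts fluoro in place of chloro without a change that can be read at the one concentration tested. This is the only step shown between compounds that differ in one place. Nothing measured here explains this outcome. The compounds shown leave open whether a methoxy group, a nitrile or an amine on this carbon would keep the number at this level. They also leave open how potency compares, since a single concentration near the top of the read-out cannot separate these compounds.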